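This account rests on a few compounds, and the source may have more. Where it says the series, first, only, none or still open, it means among the compounds named here.

Series notes. In an ADME assay on HEK-293T cells (Homo sapiens) for cytotoxicity, with a stated time of 48 h (on this read-out higher numbers stand for lower toxicity in this test and lower numbers for higher toxicity in this test), compound 1 `CCc1ncnc(NC(C)c2ccc3ccccc3c2)c1Cl` gives > 10000 nM, a limit of the assay and not a number. Compound 2 `CCc1ncnc(NC(C)c2sc3ccccc3c2C)c1Cl` gives > 10000 nM in this assay, again a limit. Compound 3 `CCC(Nc1cc(C)ncn1)c1ccc(Oc2ccc(F)cc2)cc1` likewise sits at a limit, > 10000 nM in this assay, so compound 3 stands with the whole set at the limit of > 10000 nM in this assay, at which 3 of the 3 values shown sit, rather than at any measured number. Compound 4 `CCC(Nc1nc(C)nc(Cl)c1N)c1ccc(Oc2ccc(F)cc2)cc1` is not yet measured in this assay; it differs from compound 3 by 5-amino-6-chloro-2-methylpyrimidin-4-yl in place of 6-methylpyrimidin-4-yl on an amine nitrogen. Within the data shown here, no measured step is available to anchor this change. Because every reading so far is a limit (the limit of > 10000 nM in this assay, at which 3 of the 3 values shown sit), the step from compound 3 to compound 4 is expected to be none beyond the scatter, a step that the limit leaves unreadable from compound 3 to compound 4. Compound 4 is estimated at 15000 nM in this assay, within 5000 nM to 40000 nM, with a further limit reading the most likely outcome.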

Compound 4, half-maximal cytotoxic concentration: > 10000 nM
Compound 4 was reported as a limit (the forecaster's own chance of this, stated with the estimate: 70%); the middle value lies beyond the limit too.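

No step can be read between compound 3 and compound 4, each reported only as a limit in this assay: the limit of > 10000 nM in this assay, at which 4 of the 4 values shown sit.

The compounds shown leave open at what concentration, if any, any of them becomes cytotoxic.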